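Quinazoline thioether series, phosphodiesterase 7 inhibition

A few compounds are considered here, and "the series" means these few. Any claim that something is new, unique, unknown or untested is made for them only; others in the source may bear on it.

Measured compounds:
compound 1 `Cc1nc(SCc2ccc(-c3ccccc3C#N)cc2)c2ccccc2n1`: > 100000 nM
compound 2 `COC(=O)c1ccccc1-c1ccc(CSc2nc(C(C)C)nc3ccccc23)cc1`: > 100000 nM

In an assay on isolated protein for inhibition of phosphodiesterase 7 (Homo sapiens), read by scintillation proximity assay and cAMP accumulation, with a stated time of 1 h (on this read-out lower numbers stand for stronger inhibition and higher numbers for weaker inhibition), compound 1 reports only a limit, > 100000 nM. Compound 2 likewise reports only a limit, > 100000 nM. Within the data shown here, both values shown sit at the limit of > 100000 nM in this assay, at which 2 of the 2 values shown sit; compound 2 therefore stands at the limit and nowhere on a numerical scale, as does the one other value shown.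

Compound 3 `CC(C)c1nc(SCc2ccc(-c3cccc(C(=O)O)c3)cc2)c2ccccc2n1` differs from compound 2 by 3-carboxyphenyl in place of 2-(methoxycarbonyl)phenyl on an aromatic carbon, para to a large group. Among the measured compounds shown here, no measured step covers such a change. With both measured values at the limit, the step is expected to be none beyond the scatter, an at least 1.2-fold lower number from compound 2 to compound 3 (0.09 log units; that floor lies within the scatter). Compound 3 is expected at 80000 nM in this assay, within 15000 nM to 300000 nM, most likely again reported only as a limit.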

Compound 3, half-maximal inhibitory concentration: 850 nM
Compound 3: the middle estimate sits 94-fold (1.97 log units) above what was measured; measured number below the stated range.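

Activity in this series responds to the group at this aromatic carbon: 3-carboxyphenyl in place of 2-(methoxycarbonyl)phenyl gives an at least 110-fold lower number from compound 2 to compound 3 (2.07 log units; beyond the scatter) in this assay, and compound 3 alone here carries a number rather than a limit. The size of the step is only a floor, since compound 2 stands at a limit: the limit of > 100000 nM in this assay, at which 2 of the 3 values shown sit. The change alters the group and its substitution pattern together, so this single step cannot separate the two.

Which of the two carries the step stays open. So does the outcome with an amide or a tetrazole on the same ring.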